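From 2,3-dichlorophenyl to 3-bromophenyl: notes on compound 4

The source may hold more compounds than are shown below. What is called first, only, known or untested is meant among the compounds shown, and "the series" means these compounds.

Values in a functional assay on MDA-MB-231 cells (Homo sapiens) for antiproliferative activity, read by MTT assay, with a stated time of 72 h (on this read-out lower numbers stand for stronger inhibition and higher numbers for weaker inhibition), so far:
compound 1 `NC1=NC2(CCOCC2)N(OCCCOc2ccc(Cl)cc2)C(N)=N1` gives "not determined" (no result reported)
compound 2 `NC1=NC2(CCSCC2)N(OCCCOc2cccc(Cl)c2Cl)C(N)=N1` gives 1 nM
compound 3 `NC1=NC2(CCOCC2)N(OCCCOc2cc(Cl)c(Cl)cc2Cl)C(N)=N1` gives "not determined" (no result reported)

Among the compounds with values here, compound 2 at 1 nM holds the only number, since compound 1 and compound 3 have no result, so it cannot be ranked against them. Within the data shown here, no measured step exists either. Going to compound 4 `NC1=NC2(CCSCC2)N(OCCCOc2cccc(Br)c2)C(N)=N1` the change is 3-bromophenyl in place of 2,3-dichlorophenyl on an oxygen on a saturated carbon and it sits on an oxygen on a saturated carbon, with the shared core unchanged. With compound 2 at 1 nM as a very low lone number, a step beyond the scatter toward weaker inhibition is expected in this assay for this replacement. The estimated move is a 10-fold higher number from compound 2 to compound 4 (1.00 log units; beyond the scatter) toward weaker inhibition. For compound 4 the estimate is 10 nM with an expected range from 1.5 nM to 80 nM in this read-out.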

Compound 4, half-maximal inhibitory concentration: 60 nM
For compound 4 the middle estimate is 6.0-fold (0.78 log units) below the measured one; measured number inside the range.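

In this assay the series now has its first measured step at this place: 3-bromophenyl in place of 2,3-dichlorophenyl on an oxygen on a saturated carbon gives a 60-fold higher number from compound 2 to compound 4 (1.78 log units; beyond the scatter). The read-out therefore responds strongly to this aryl group alone, with the shared core unchanged. Nothing measured here bears on the reason for the step.

Compound 2 and compound 4 differ in both halogen type and halogen count, so the contribution of each remains unresolved. From the compounds shown here alone, how a 3-chlorophenyl group or a longer chain would read at this place also remains open.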